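From trifluoromethyl to fluoro on an aromatic carbon

The source may report more compounds than this note shows. Statements on the series, on what has been measured and on what is new or still open speak of the compounds shown alone.

Three measured compounds share one core and differ only in the group on a carbonyl carbon. In a functional assay on K562 cells (Homo sapiens) for cytotoxicity, read by MTT assay, with a stated time of 72 h (a higher number here means a weaker inhibitor, a lower number a stronger inhibitor), compound 1 `C=C1C(=O)[C@@]23C(=O)OC[C@]4(C(=O)CCC(C)(C)[C@H]4C=O)[C@@H]2CC[C@@H]1[C@H]3OC(=O)CC`, with ethyl, gives 1310 nM. Compound 2 `C=C1C(=O)[C@@]23C(=O)OC[C@]4(C(=O)CCC(C)(C)[C@H]4C=O)[C@@H]2CC[C@@H]1[C@H]3OC(=O)c1ccccc1`, with phenyl, gives 1480 nM, and compound 3 `C=C1C(=O)[C@@]23C(=O)OC[C@]4(C(=O)CCC(C)(C)[C@H]4C=O)[C@@H]2CC[C@@H]1[C@H]3OC(=O)c1ccc(C(F)(F)F)cc1`, with 4-(trifluoromethyl)phenyl, gives 2820 nM. Compound 3 stands clear of only one of the other two: there is a 2.2-fold higher number from compound 1 to compound 3 (0.33 log units; beyond the scatter), but only a 1.9-fold higher number from compound 2 to compound 3 (0.28 log units; within the scatter).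

Compound 4 `C=C1C(=O)[C@@]23C(=O)OC[C@]4(C(=O)CCC(C)(C)[C@H]4C=O)[C@@H]2CC[C@@H]1[C@H]3OC(=O)c1ccc(F)cc1` has not yet been measured. Its difference from compound 3 is a single group: fluoro in place of trifluoromethyl on an aromatic carbon. In words, fluoro takes the place of trifluoromethyl on an aromatic carbon, para to a large group.

The closest guide is the step that put trifluoromethyl in place of hydrogen on that aromatic carbon, a 1.9-fold higher number from compound 2 to compound 3 (0.28 log units; within the scatter). A smaller group there may undo part of that small step, so a slightly lower number is expected. The swap of ethyl for phenyl, a 1.1-fold higher number from compound 1 to compound 2 (0.05 log units; within the scatter), also suggests that this part of the molecule moves the number little. In this assay the expected change is a 1.6-fold lower number from compound 3 to compound 4 (0.19 log units; within the scatter), which would stay within the scatter. For compound 4 the estimate is 1800 nM, with an expected range from 950 nM to 3300 nM.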

Compound 4, half-maximal inhibitory concentration: 2700 nM
Compound 4: middle estimate off by 1.5-fold (0.18 log units), on the low side, and the stated range covers the measured number.
By their numbers in this assay, from the lowest: compounds 1, 2, 4 and 3 (each within the scatter of the next, the first and the last beyond it).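

In this assay, swapping trifluoromethyl for the much smaller fluoro leaves the reading essentially where it was (a 1.0-fold lower number from compound 3 to compound 4 (0.02 log units; within the scatter)), so across these two groups the number at this aromatic carbon does not follow the count of heavy atoms. Compound 4 also cannot be separated from the unsubstituted phenyl ester (a 1.8-fold higher number from compound 2 to compound 4 (0.26 log units; within the scatter)), yet it does stand modestly clear of the ethyl ester (a 2.1-fold higher number from compound 1 to compound 4 (0.31 log units; beyond the scatter)), the same small separation that compound 3 shows from compound 1, whereas compound 2 shows none from compound 1. No measurement is at hand that could explain why fluoro and trifluoromethyl read alike here.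

The compounds shown leave open whether this aromatic carbon would respond to a group of a different kind, such as an amine, a hydroxyl or a carboxylic acid, since all the values so far lie close together. They also leave open whether a longer chain in place of ethyl on the carbonyl carbon would move the number further than any of these aromatic groups.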